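Compound 4 and the limit of the series

A few compounds are considered here, and "the series" means these few. Any claim that something is new, unique, unknown or untested is made for them only; others in the source may bear on it.

Compound 1 `O=C1c2c[n+]([O-])c3ccccc3c2C(=O)c2c1c1ccccc1n2Cc1cn(C[C@H](O)CO)nn1`, compound 2 `O=C1c2c[n+]([O-])c3ccccc3c2C(=O)c2c1c1ccccc1n2Cc1cn(CC(O)CO)nn1`, compound 3 `CC1(C)OC[C@@H](Cn2cc(Cn3c4c(c5ccccc53)C(=O)c3c[n+]([O-])c5ccccc5c3C4=O)nn2)O1` and the unmeasured compound 4 `O=C1c2c[n+]([O-])c3ccccc3c2C(=O)c2c1c1ccccc1n2Cc1cn([C@H]2C[C@H](O)[C@@H](CO)O2)nn1` share one core. In a functional assay on SH-SY5Y cells (Homo sapiens) for cytotoxicity, read by MTT assay, with a stated time of 72 h (a lower number here means a stronger inhibitor, a higher number a weaker inhibitor), compound 1 gives > 1000 nM, a limit. Compound 2 gives > 1000 nM, also a limit. Compound 3 gives > 1000 nM, likewise a limit. The series therefore rests on (the limit of > 1000 nM in this assay, at which 3 of the 3 values shown sit). The next change is 4-hydroxy-5-(hydroxymethyl)oxolan-2-yl in place of (2,2-dimethyl-1,3-dioxolan-4-yl)methyl on an aromatic nitrogen. The measured steps that bear on it, a step that the two limits leave unreadable from compound 1 to compound 3 and a step that the two limits leave unreadable from compound 2 to compound 3, also alter the group on the triazole-free side of no known size, so they offer no direction for this assay.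

Correction to the line above: those two steps alter the substituent carried on the aromatic nitrogen, and neither has a readable size, so no direction is expected. The expected step is a step that the limit leaves unreadable from compound 3 to compound 4, and another limit is the likeliest result. For compound 4 the estimate is 3000 nM, with an expected range from 1000 nM to 20000 nM.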

Compound 4, half-maximal inhibitory concentration: 620 nM
Compound 4: the middle estimate sits 4.8-fold (0.68 log units) above what was measured; measured number below the stated range.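

In this assay, for the compounds shown here, compound 4 gives 620 nM, the first number that is not a limit, so the group on the aromatic nitrogen can now be tied to a measured value. The steps are an at least 1.6-fold lower number from compound 3 to compound 4 (0.20 log units; that floor lies within the scatter), an at least 1.6-fold lower number from compound 2 to compound 4 (0.20 log units; that floor lies within the scatter) and an at least 1.6-fold lower number from compound 1 to compound 4 (0.20 log units; that floor lies within the scatter); each is only a floor, and each floor lies within the scatter. The true size of all three stays unknown, and the reason they are floors is the limit: the limit of > 1000 nM in this assay, at which 3 of the 4 values shown sit.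

Still open, going by these compounds, is whether the oxolane ring itself or its hydroxyl groups go with the value of compound 4. An amine or a carboxylic acid in place of the hydroxymethyl would test this.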